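This account rests on a few compounds, and the source may have more. Where it says the series, first, only, none or still open, it means among the compounds named here.

Compound 1 `COc1cncc(N2CC[C@@H]3CN[C@@H]3C2)c1` is the weakest performer of the three: in a functional assay on HEK293 cells for agonist activity at Neuronal acetylcholine receptor; alpha4/beta2 (Homo sapiens), read by FLIPR (on this read-out higher numbers stand for an effect only at larger amounts of compound and lower numbers for an effect already at smaller amounts), compound 1 gives 2700 nM, while compound 2 `CCOc1cncc(N2CC[C@@H]3CN[C@@H]3C2)c1` gives 1350 nM and compound 3 `Cc1cncc(N2CC[C@@H]3CN[C@@H]3C2)c1` gives 650 nM. The steps among them, a 2.0-fold lower number from compound 1 to compound 2 (0.30 log units; within the scatter), a 4.2-fold lower number from compound 1 to compound 3 (0.62 log units; beyond the scatter) and a 2.1-fold lower number from compound 2 to compound 3 (0.32 log units; beyond the scatter), all concern the group on the aromatic carbon and were modest at most. Compound 4 `COc1cc(N2CC[C@@H]3CN[C@@H]3C2)cnc1Br` differs from compound 1 by bromo in place of hydrogen on an aromatic carbon, on the carbon next to the ring nitrogen, ortho to the methoxy group. Among the measured compounds shown here, no measured step touches that position, so nothing here predicts its effect; the author therefore expects no step beyond the scatter, a 1.4-fold lower number from compound 1 to compound 4 (0.13 log units; within the scatter). Compound 4 is estimated at 2000 nM, within 500 nM to 8000 nM.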

Compound 4, half-maximal effective concentration: 360 nM
Compound 4: the middle estimate sits 5.6-fold (0.74 log units) above what was measured; the measured number lies below the stated range.
By their numbers in this assay, from the lowest: compounds 4 and 3 (each within the scatter of the next); then compounds 2 and 1 (each within the scatter of the next).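

Bromo in place of hydrogen on an aromatic carbon, next to the ring nitrogen and ortho to a methoxy group, gives a 7.5-fold lower number from compound 1 to compound 4 (0.88 log units; beyond the scatter) in this assay. The earlier steps shown here all concerned the methoxy group and its replacements, whereas this one shows that adding a single heavy atom at a different position can also move the number beyond the scatter. Nothing available explains this shift.

Going by these compounds, whether the shift is specific to bromo or would also appear with chloro, fluoro or a nitrile remains open. It is also unknown whether bromo would act alike with the ethoxy group of compound 2 or the methyl group of compound 3.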